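The compounds below may be only part of what the source reports. "The series", "measured", "known", "first", "only" and "open" are said of these compounds alone.

Compound 1 `Cn1c(N2N=C(c3ccccc3)CC2c2ccc(F)cc2)nc(-c2ccccc2)c(C#N)c1=O` and compound 2 `Cc1ccc(C2=NN(c3nc(-c4ccccc4)c(C#N)c(=O)n3C)C(c3ccc(F)cc3)C2)cc1` share one core and differ on a single aromatic carbon. In a functional assay on MCF7 cells (Homo sapiens) for antiproliferative activity, with a stated time of 72 h (a lower number here means a stronger inhibitor, a higher number a weaker inhibitor), compound 1 gives 38100 nM, and in this assay compound 2 gives 23100 nM. For the measured compounds named here, the step of a 1.6-fold lower number from compound 1 to compound 2 (0.22 log units; within the scatter) lies within the scatter, so the two numbers are not told apart; compound 2 simply sits alongside compound 1, and there is no other measured compound for comparison. Compound 3 `Cc1ccc(C2=NN(c3nc(-c4ccc(Cl)cc4)c(C#N)c(=O)n3C)C(c3ccc(F)cc3)C2)cc1` carries chloro in place of hydrogen on an aromatic carbon. Going by the values given here, no measured step concerns a chloro on that ring; the single measured step, a 1.6-fold lower number from compound 1 to compound 2 (0.22 log units; within the scatter), touches a different ring and was itself within the scatter. With nothing pointing either way, compound 3 is expected to give a number close to that of compound 2, the step of a 1.0-fold lower number from compound 2 to compound 3 (0.00 log units; within the scatter) expected to stay within the scatter. The estimate for compound 3 is therefore 23000 nM, expected between 8000 nM and 65000 nM.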

Compound 3, half-maximal inhibitory concentration: 116000 nM
Beside the measured number, compound 3's estimate is 5.0-fold (0.70 log units) below it; the measured number lies above the stated range.
By their numbers in this assay, from the lowest: compounds 2 and 1 (each within the scatter of the next); then compound 3.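

In this assay, for the compounds shown here, chloro in place of hydrogen on this ring, para to a large group, gives the first step that can be read as a real change: a 5.0-fold higher number from compound 2 to compound 3 (0.70 log units; beyond the scatter). A higher number means a weaker inhibitor, so this position does respond to substitution, and here the response is a loss of activity, whereas the methyl change on a different ring, a 1.6-fold lower number from compound 1 to compound 2 (0.22 log units; within the scatter), could not be told from the scatter. Nothing available explains why the chloro has this effect.

From the compounds shown here alone, whether the loss belongs to chloro itself or would follow any group at this position remains open, since a single substituent cannot show how a fluoro, a methoxy or an amine would behave there. Going by these compounds, it is also open whether the same step would appear without the methyl that compound 2 carries.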